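Swapping the aryl group on the hydrazone carbon

The compounds below may be only part of what the source reports. "The series", "measured", "known", "first", "only" and "open" are said of these compounds alone.

Measured so far in a functional assay on NCI-H460 cells (Homo sapiens) for cytotoxicity, read by MTT assay, with a stated time of 72 h; a lower number here means a stronger inhibitor, a higher number a weaker inhibitor:
- compound 1 `COc1ccc(/C=N/NC(=O)Nc2ccc(Oc3ccnc(-c4nncn4CCN(C)C)c3)c(F)c2)c(OC)c1`: compound 1 gives 1570 nM
- compound 2 `CN(C)CCn1cnnc1-c1cc(Oc2ccc(NC(=O)N/N=C/c3ccc(O)c(O)c3)cc2F)ccn1`: compound 2 gives 1930 nM
- compound 3 `CN(C)CCn1cnnc1-c1cc(Oc2ccc(NC(=O)N/N=C/c3cccc(Cl)c3Cl)cc2F)ccn1`: compound 3 gives 72 nM

Compound 3 holds the lowest number of the three. The step of a 22-fold lower number from compound 1 to compound 3 (1.34 log units; beyond the scatter) and the step of a 27-fold lower number from compound 2 to compound 3 (1.43 log units; beyond the scatter) are both large and beyond the scatter, while a 1.2-fold higher number from compound 1 to compound 2 (0.09 log units; within the scatter) is within the scatter, so the aryl group on the carbon with a double bond to nitrogen is the one place where this series has so far moved.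

Going by the values given here, compound 4 `CN(C)CCn1cnnc1-c1cc(Oc2ccc(NC(=O)N/N=C/c3ccc(Cl)cc3)cc2F)ccn1` keeps the shared core and changes only that aryl group: 4-chlorophenyl in place of 2,3-dichlorophenyl on a carbon with a double bond to nitrogen. Among the compounds with values here, none of the measured steps bears directly on this exchange; they show only that the 2,3-dichlorophenyl of compound 3 stands far below the 2,4-dimethoxyphenyl of compound 1 and the 3,4-dihydroxyphenyl of compound 2. Compound 4 retains a chlorine on the ring but loses one and shifts the pattern, so the account expects a number somewhat above that of compound 3, closer to it than to compounds 1 and 2, with a step of a 2.8-fold higher number from compound 3 to compound 4 (0.44 log units; beyond the scatter). Compound 4 is therefore estimated at 200 nM, within a range from 60 nM to 700 nM.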

Compound 4, half-maximal inhibitory concentration: 320 nM
Beside the measured number, compound 4's estimate is 1.6-fold (0.20 log units) below it, within the range that was stated.
By their numbers in this assay, from the lowest: compound 3; then compound 4; then compounds 1 and 2 (each within the scatter of the next).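

In this assay, the change from 2,3-dichlorophenyl to 4-chlorophenyl on the carbon with a double bond to nitrogen gives a modest step beyond the scatter (a 4.4-fold higher number from compound 3 to compound 4 (0.65 log units; beyond the scatter)), so this position separates two chlorinated aryl groups from each other, and not only chlorinated groups from the 2,4-dimethoxyphenyl and 3,4-dihydroxyphenyl groups. The 4-chlorophenyl group nevertheless remains clearly apart from both of those groups (a 4.9-fold lower number from compound 1 to compound 4 (0.69 log units; beyond the scatter); a 6.0-fold lower number from compound 2 to compound 4 (0.78 log units; beyond the scatter)), which places compound 4 at an intermediate level and shows that the low numbers at this position are not confined to compound 3. Nothing available explains why the position responds in this way.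

Compound 4 both has one chlorine fewer than compound 3 and has a different chlorine pattern, so these compounds cannot show how much of the step belongs to each change. On these data alone, it also remains open how 2-chlorophenyl or 3-chlorophenyl would stand at this position, and whether an aryl group carrying an amine or a carboxylic acid would follow the chlorinated groups or the other two.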